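The source may hold more compounds than are shown below. What is called first, only, known or untested is meant among the compounds shown, and "the series" means these compounds.

Measured so far:
- compound 1 `CCS(=O)(=O)Nc1cc(-c2ccc3ncnc(Nc4cccc(C(=O)OC)c4)c3c2)cnc1OC` gives 2400 nM
- compound 2 `CCS(=O)(=O)Nc1cc(-c2ccc3ncnc(Nc4ccc(Cl)c(C(=O)OC)c4)c3c2)cnc1OC` gives 7060 nM

Both numbers come from a functional assay on SK-HEP1 cells (Homo sapiens) for cytotoxicity, read by sulforhodamine B assay, with a stated time of 72 h; on this read-out lower numbers stand for stronger inhibition and higher numbers for weaker inhibition. On these two results compound 2 stands highest: against compound 1 the change is a 2.9-fold higher number from compound 1 to compound 2 (0.47 log units; beyond the scatter), a chloro in place of hydrogen on an aromatic carbon.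

Compound 3 `CCS(=O)(=O)Nc1cc(-c2ccc3ncnc(Nc4ccc(C(=O)OC)c(OC)c4)c3c2)cnc1OC` has not yet been measured. It differs from compound 2 in one place: 3-methoxy-4-(methoxycarbonyl)phenyl in place of 4-chloro-3-(methoxycarbonyl)phenyl on a nitrogen on an aromatic ring. This change removes the chloro again and brings in a methoxy, while the methoxycarbonyl group keeps its place on the same ring.

For the measured compounds named here, the only measured step, a 2.9-fold higher number from compound 1 to compound 2 (0.47 log units; beyond the scatter), shows that adding the chloro raised the number; taking it away in compound 3 might undo part of that. Nothing measured here tells what the added methoxy does. The step from compound 2 to compound 3 is therefore expected to be a 1.9-fold lower number from compound 2 to compound 3 (0.27 log units; within the scatter), toward a lower number, with little certainty. For compound 3 the estimated result is 3800 nM, with a range from 1200 nM to 12000 nM.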

Compound 3, half-maximal inhibitory concentration: 830 nM
For compound 3 the middle estimate is 4.6-fold (0.66 log units) above the measured one; measured number outside the range, below it.
By their numbers in this assay, from the lowest: compound 3; then compound 1; then compound 2.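

In this assay the group on this nitrogen can lower the number as well as raise it: 3-methoxy-4-(methoxycarbonyl)phenyl gives a 2.9-fold lower number from compound 1 to compound 3 (0.46 log units; beyond the scatter) and also an 8.5-fold lower number from compound 2 to compound 3 (0.93 log units; beyond the scatter) in the same direction. The group names show that, compared with compound 1, this change does two things at once, bringing in a methoxy and moving the methoxycarbonyl from the 3 to the 4 position of the name, so neither part alone can be credited with the step. No data here explain why the number falls.

A compound carrying 4-(methoxycarbonyl)phenyl without the methoxy would separate those two parts. As far as these compounds go, how a carboxylic acid or an amide would compare with the methoxycarbonyl, or an amine with the methoxy, also remains open.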